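The compounds below may be only part of what the source reports. "The series", "measured", "known", "first", "only" and "open" are said of these compounds alone.

Series notes. Compound 1 `COc1cc(-n2cnc3ccc(-c4cccc(F)c4)cc32)cc(OC)c1OC` gives 5270 nM in a functional assay on A549 cells (Homo sapiens) for antiproliferative activity, read by MTT assay, with a stated time of 72 h; on this read-out higher numbers stand for weaker inhibition and lower numbers for stronger inhibition. Compound 2 `COc1cc(-n2cnc3ccc(-c4ccccc4)cc32)cc(OC)c1OC` gives 3060 nM in this assay. Within the data shown here, the only single-point step measured so far, a 1.7-fold lower number from compound 1 to compound 2 (0.24 log units; within the scatter), is hydrogen in place of fluoro on an aromatic carbon, and it does not separate the two compounds. Compound 2 thus holds the smaller of the two numbers, but with the step to compound 1 inside the scatter nothing more can be read into that.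

Compound 3 `COc1cc(-n2cnc3ccc(-c4cccc([N+](=O)[O-])c4)cc32)cc(OC)c1OC` differs from compound 2 by nitro in place of hydrogen on an aromatic carbon. Among the measured compounds shown here, no measured step involves a nitro group; the step of a 1.7-fold lower number from compound 1 to compound 2 (0.24 log units; within the scatter), which exchanged fluoro for hydrogen, is the only one that bears on this kind of change, and it lay within the scatter. As far as these compounds go, on that basis no step beyond the scatter is expected in this assay in either direction, with the range kept wide as this exchange itself is untested. For compound 3 the expected step is a 1.3-fold higher number from compound 2 to compound 3 (0.12 log units; within the scatter). Compound 3 is therefore estimated at 4000 nM in this assay, with a range from 1500 nM to 12000 nM.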

Compound 3, half-maximal inhibitory concentration: 5410 nM
For compound 3 the middle estimate is 1.4-fold (0.13 log units) below the measured one; measured number inside the range.
By their numbers in this assay, from the lowest: compounds 2, 1 and 3 (each within the scatter of the next).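

On the aromatic carbon meta to a large group, nitro in place of hydrogen gives a 1.8-fold higher number from compound 2 to compound 3 (0.25 log units; within the scatter) in this assay and nitro in place of fluoro gives a 1.0-fold higher number from compound 1 to compound 3 (0.01 log units; within the scatter) on the same read-out. Among these compounds, with these two steps added to the earlier one, hydrogen, fluoro and nitro have now been compared with each other at this one place, and no pair among compounds 1, 2 and 3 is separated beyond the scatter, even though nitro brings 3 heavy atoms and 2 hydrogen-bond acceptors where hydrogen brings no heavy atom. This holds for these three compounds only and makes no claim for other groups, and nothing at hand offers an explanation for this flat result.

As far as these compounds go, whether an amine, a carboxylic acid or a longer chain such as an alkoxy chain on the same aromatic carbon would produce a step beyond the scatter stays open. Also open, from the compounds shown here alone, is whether fluoro or nitro would give the same picture on another carbon of that six-membered aromatic ring, or whether changes to the shared core would move the numbers further than any change at this place has so far.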